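The compounds below may be only part of what the source reports. "The series", "measured", "known", "first", "only" and "open" are said of these compounds alone.

Measured in a functional assay on HCT-15 cells (Homo sapiens); on this read-out higher numbers stand for an effect only at larger amounts of compound and lower numbers for an effect already at smaller amounts:
- compound 1 `COc1cc(OC)c(C2OC(c3ccc(N)c(C)c3)=NN2C(C)=O)cc1OC`: 198 uM
- compound 2 `CC(=O)N1N=C(c2ccc(N(C)C)cc2)OC1c1cc(C)c(C)c(C)c1`: 1.5 uM
- compound 3 `CCOC(=O)C(=O)N1N=C(c2ccc(N(C)C)cc2)OC1c1cc(OC)c(OC)c(OC)c1`: 45 uM

Compound 3 stands in the middle of the three, with a lower number than compound 1 and a higher one than compound 2, both gaps beyond the scatter. Compound 4 `COc1cc(C2OC(c3ccc(N(C)C)cc3)=NN2C(=O)CO)cc(OC)c1OC` differs from compound 3 in one place: hydroxymethyl in place of ethoxycarbonyl on a carbonyl carbon. Among the compounds with values here, no measured pair isolates this change, so the expectation is weak and rests mainly on the value of compound 3, 45 uM. A modest move towards a lower number is expected in this assay, an estimated 1.8-fold lower number from compound 3 to compound 4 (0.26 log units; within the scatter). For compound 4 the estimated value is 25 uM, with an expected range of 6 uM to 100 uM.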

Compound 4, concentration for half-maximal effect: 0.026 uM
For compound 4 the middle estimate is 960-fold (2.98 log units) above the measured one; the whole stated range lies above it.
By their numbers in this assay, from the lowest: compound 4; then compound 2; then compound 3; then compound 1.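

In this assay hydroxymethyl in place of ethoxycarbonyl on a carbonyl carbon gives a 1700-fold lower number from compound 3 to compound 4 (3.24 log units; beyond the scatter) and so shows that this one group, on a carbonyl carbon bound to an amide-type nitrogen in a ring, can move the read-out very far. The earlier compounds shown here differ in more than one place and could not show this. Nothing shown accounts for the size of the step. Still open, on these data alone, is whether the hydroxyl oxygen itself matters, or whether methoxymethyl, aminomethyl or a longer hydroxyalkyl chain on the same carbonyl carbon would give a similar number.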